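From sec-butyl to tert-butyl on a shared core

This account rests on a few compounds, and the source may have more. Where it says the series, first, only, none or still open, it means among the compounds named here.

In a functional assay on the whole organism with Scenedesmus acutus as the target (on this read-out higher numbers stand for weaker inhibition and lower numbers for stronger inhibition), compound 1 `COC(=O)c1cc(N2C(=O)C3=C(CCCC3)C2=O)ccc1Cl` gives 2000 nM. Sharing the core of compound 1, compound 2 `CCC(C)OC(=O)c1cc(N2C(=O)C3=C(CCCC3)C2=O)ccc1Cl` gives 794 nM, the lowest of the two numbers measured so far.

Compound 3 `CC(C)(C)OC(=O)c1cc(N2C(=O)C3=C(CCCC3)C2=O)ccc1Cl` remains unmeasured. It carries tert-butyl in place of sec-butyl on an oxygen next to a carbonyl group, and its difference from compound 2 comes to tert-butyl in place of sec-butyl on an oxygen next to a carbonyl group. The two compounds have the same atoms, joined differently.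

Within the data shown here, only one measured step bears on this change: a 2.5-fold lower number from compound 1 to compound 2 (0.40 log units; beyond the scatter). That modest step replaced methyl with sec-butyl, so it altered the size of the group. Among the measured compounds shown here, the new change leaves the count of heavy atoms the same, and no measured pair isolates a rearrangement of this kind. Only a small shift is therefore expected in this assay, with no firm direction and probably none beyond the scatter. The expected change is a 1.1-fold higher number from compound 2 to compound 3 (0.05 log units; within the scatter). Compound 3 is estimated at 900 nM, with an expected range from 350 nM to 2300 nM.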

Compound 3, half-maximal inhibitory concentration: 12900 nM
The estimate for compound 3 lay 14-fold (1.16 log units) below the measured number, outside the stated range (above it).
By their numbers in this assay, from the lowest: compound 2; then compound 1; then compound 3.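

In this assay, this position on an oxygen next to a carbonyl group proves sensitive to how the carbons are joined and not only to how many there are: the swap of sec-butyl for tert-butyl, with the count of heavy atoms unchanged, gives a 16-fold higher number from compound 2 to compound 3 (1.21 log units; beyond the scatter). The effect of replacing methyl therefore depends on the group that enters, since a 2.5-fold lower number from compound 1 to compound 2 (0.40 log units; beyond the scatter) with sec-butyl, whereas tert-butyl gives a 6.5-fold higher number from compound 1 to compound 3 (0.81 log units; beyond the scatter), so these two groups of the same size move the number in opposite directions. Nothing measured here accounts for the gap between these two arrangements of the same atoms.

The compounds shown leave open where an isopropyl group, an isobutyl group or a straight butyl chain would fall at this position, and so whether tert-butyl stands alone or belongs to a wider trend. Also open, on these data alone, is whether the change from sec-butyl to tert-butyl would have the same size on a different core, as it is seen here on the shared core alone.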